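The source may report more compounds than this note shows. Statements on the series, on what has been measured and on what is new or still open speak of the compounds shown alone.

Compound 1, `CCCCNc1nc(N)nc(C)c1CCCN1CCCCCC1`: in an assay on HEK293 cells for agonist activity at Toll-like receptor 8 (Homo sapiens), read by spectrophotometry (on this read-out lower numbers stand for an effect already at smaller amounts and higher numbers for an effect only at larger amounts of compound), compound 1 gives 178 nM.
Compound 2, `CCCCNc1nc(N)nc(C)c1C`: compound 2 gives 3280 nM.
Compound 3, `CCCCNc1nc(N)nc(C)c1CCCN1CCCCC1`: compound 3 gives 133 nM.

Compound 3 has the lowest of the three numbers. Its nearest neighbour is compound 1, with a 1.3-fold lower number from compound 1 to compound 3 (0.13 log units; within the scatter), so the two cannot be told apart. Compound 2, which has only a methyl where the others carry the amine-bearing chain, gives a much higher number than compound 3.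

Compound 4, `CCCCNc1nc(N)nc(C)c1CCCN(C)C`, keeps the chain but changes the amine at its end: dimethylamino in place of piperidin-1-yl on a saturated chain carbon, three bonds along the chain from an aromatic carbon. Among the compounds with values here, the only measured step at this place is the one from azepanyl to piperidinyl, a 1.3-fold lower number from compound 1 to compound 3 (0.13 log units; within the scatter), which did not move the number beyond the scatter. Within the data shown here, that step shows that the size of the saturated amine ring matters little here, but no measured compound removes the ring altogether, so the reach of that finding to a dimethylamino group is uncertain. The expectation for compound 4 is therefore a small shift, a 1.9-fold higher number from compound 3 to compound 4 (0.27 log units; within the scatter), within or just beyond the scatter. The estimate for compound 4 in this assay is 250 nM, with a range of 90 nM to 700 nM.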

Compound 4, half-maximal effective concentration: 126 nM
The estimate for compound 4 lay 2.0-fold (0.30 log units) above the measured number; the range from low to high includes it.
By their numbers in this assay, from the lowest: compounds 4, 3 and 1 (each within the scatter of the next); then compound 2.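

In this assay, the saturated amine ring proves dispensable at the end of the chain: dimethylamino in place of piperidin-1-yl gives a 1.1-fold lower number from compound 3 to compound 4 (0.02 log units; within the scatter), and dimethylamino in place of azepan-1-yl gives a 1.4-fold lower number from compound 1 to compound 4 (0.15 log units; within the scatter), so compounds 1, 3 and 4 cannot be told apart although compound 4 carries no ring there. The large step stays with the amine-bearing chain as a whole: 2-(dimethylamino)ethyl in place of hydrogen on a saturated chain carbon bound to an aromatic carbon gives a 26-fold lower number from compound 2 to compound 4 (1.42 log units; beyond the scatter), so among these compounds the distance from compound 2 does not depend on a ring at the chain end. No evidence is at hand on why these three amines read alike.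

Every chain shown ends in a tertiary amine, so it remains open whether a hydroxyl group or a bare propyl chain would keep the number. Also open, going by these compounds, is how a primary amine, or a longer chain ending in dimethylamino, would read.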